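Trading Azetidine for Difluoroethyl in a Benzamide Series

The source may report more compounds than this note shows. Statements on the series, on what has been measured and on what is new or still open speak of the compounds shown alone.

Measured compounds in an ADME assay on microsomes from liver (Rattus norvegicus, strain Sprague-Dawley) for metabolic stability, read by HPLC, using NADPH, with stated times of 5 min and 60 min, tested at 10 uM; on this read-out lower numbers stand for slow clearance and higher numbers for fast clearance:
compound 1, `CC(C)S(=O)(=O)Nc1ccc(CNC(=O)c2ccc(C(C)(C)C)cc2)c(Cl)c1` — 23 mL.min-1.g-1
compound 2, `CC(C)(C)c1ccc(C(=O)NCc2ccc(NS(=O)(=O)C3CC3)cc2Cl)cc1` — 41 mL.min-1.g-1
compound 3, `CS(=O)(=O)Nc1ccc(CNC(=O)c2ccc(N3CCC3)cc2)c(Cl)c1` — 8.6 mL.min-1.g-1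

Among these three, compound 3 stands lowest; compound 1 lies nearest to it, and compound 2 furthest. Going by the values given here, the one step between measured compounds that differ in a single place, a 1.8-fold higher number from compound 1 to compound 2 (0.25 log units; within the scatter), concerns the group on the sulfonyl sulfur and not the aromatic carbon where compound 4 departs from compound 3.

Compound 4, `CC(F)(F)c1ccc(C(=O)NCc2ccc(NS(C)(=O)=O)cc2Cl)cc1`, differs from compound 3 as follows: 1,1-difluoroethyl in place of azetidin-1-yl on an aromatic carbon.

Among the compounds with values here, no measured step bears on this change, so nothing in the data sets its size or direction. What can be said is that compound 1 and compound 2 carry a tert-butyl group at that aromatic carbon and give higher numbers in this assay than compound 3. For compound 4 a modest rise from the value of compound 3 is therefore expected, a 1.7-fold higher number from compound 3 to compound 4 (0.24 log units; within the scatter), with wide uncertainty. The estimate for compound 4 is 15 mL.min-1.g-1, within a range from 5 mL.min-1.g-1 to 45 mL.min-1.g-1.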

Compound 4, intrinsic clearance in microsomes: 9.6 mL.min-1.g-1
For compound 4 the middle estimate is 1.6-fold (0.19 log units) above the measured one; the range from low to high includes it.
By their numbers in this assay, from the lowest: compounds 3 and 4 (each within the scatter of the next); then compounds 1 and 2 (each within the scatter of the next).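

In this assay, going by these compounds alone, 1,1-difluoroethyl in place of azetidin-1-yl on the aromatic carbon para to a large group gives a 1.1-fold higher number from compound 3 to compound 4 (0.05 log units; within the scatter), the only measured step at this position. The group that leaves has a four-membered non-aromatic ring and a hydrogen-bond acceptor, the group that enters has neither, and yet compound 3 and compound 4 cannot be told apart on this read-out. Nothing shown here accounts for this result.

On these data alone, compound 1 and compound 2 carry tert-butyl at this aromatic carbon but differ from compound 3 in more than one place, so how tert-butyl reads on the methyl sulfonyl scaffold of compound 3 remains open. Also open, as far as these compounds go, is how other groups on this carbon would read, such as a pyrrolidine, a morpholine, a carboxylic acid or a longer chain.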